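Pyrrolidinylmethyl analogue of a resorcinol isoxazole series

The source may hold more compounds than are shown below. What is called first, only, known or untested is meant among the compounds shown, and "the series" means these compounds.

Compound 1 `CCNC(=O)c1noc(-c2cc(C(C)C)c(O)cc2O)c1-c1cc(COCC(=O)OC)no1` carries the shared core of the series, yet in a functional assay on A2780 cells (Homo sapiens) for inhibition (a higher number here means a weaker inhibitor, a lower number a stronger inhibitor), compound 1 gives "not determined" (no result reported), so it offers no anchor for what follows. Compound 2 `CCNCc1cc(-c2c(C(=O)NCC)noc2-c2cc(C(C)C)c(O)cc2O)on1` and compound 3 `CCNC(=O)c1noc(-c2cc(C(C)C)c(O)cc2O)c1-c1cc(CN(C)C)no1` were measured: in this assay compound 2 gives 45 nM, and in this assay compound 3 gives 31 nM. For the measured compounds named here, the one step between them, a 1.5-fold lower number from compound 2 to compound 3 (0.16 log units; within the scatter), shows that swapping one small amine for another at that position leaves the result essentially unchanged. Compound 4 `CCNC(=O)c1noc(-c2cc(C(C)C)c(O)cc2O)c1-c1cc(CN2CCCC2)no1` is the next member, differing from compound 1 in this way: pyrrolidin-1-yl in place of (methoxycarbonyl)methoxy on a saturated chain carbon bound to an aromatic carbon. Going by the values given here, no measured pair covers this exact exchange, but compound 4 ends up with an amine on the same saturated chain carbon that compounds 2 and 3 occupy. Because compound 3 gives 31 nM and compound 2 gives 45 nM, compound 4 is expected to fall in the same neighbourhood. Compound 4 is therefore estimated at 35 nM, with a plausible range from 15 nM to 80 nM.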

Compound 4, half-maximal inhibitory concentration: 55 nM
For compound 4 the middle estimate is 1.6-fold (0.20 log units) below the measured one, within the range that was stated.
By their numbers in this assay, from the lowest: compounds 3, 2 and 4 (each within the scatter of the next).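

Replacing an open-chain amine with a ring amine on this saturated chain carbon has little effect in this assay: the data show a 1.8-fold higher number from compound 3 to compound 4 (0.25 log units; within the scatter) and also a 1.2-fold higher number from compound 2 to compound 4 (0.09 log units; within the scatter). Pyrrolidin-1-yl therefore joins ethylamino and dimethylamino as a third amine within the scatter, and no order can be drawn among the three. The earlier compounds shown here covered only open-chain amines, whereas compound 4 shows that closing the amine into a five-membered non-aromatic ring also keeps the result in that range. Nothing available offers an explanation for this flat result.

The exchange of (methoxycarbonyl)methoxy for pyrrolidin-1-yl itself cannot be read, as compound 1 has no number to compare. Still open, on these data alone, is whether piperidine, morpholine, a carboxylic acid or a longer chain carrying the amine would stay in the same range.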